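Nitro in place of methoxy on an aromatic carbon

This account rests on a few compounds, and the source may have more. Where it says the series, first, only, none or still open, it means among the compounds named here.

In a functional assay on HCT-116 cells (Homo sapiens) for antiproliferative activity, with a stated time of 72 h (on this read-out lower numbers stand for stronger inhibition and higher numbers for weaker inhibition), compound 1 `CC(=O)Oc1cccc(/C=C/c2nc3ccccc3c(=O)[nH]2)c1` gives 15300 nM. Compound 2 `COc1cccc(/C=C/c2nc3ccccc3c(=O)[nH]2)c1` stands only at > 25000 nM, which is a limit of the assay and not a number. Compound 3 `O=c1[nH]c(/C=C/c2cccc([N+](=O)[O-])c2)nc2ccccc12` has nitro in place of methoxy on an aromatic carbon, meta to a large group: nitro in place of methoxy on an aromatic carbon. Among the measured compounds shown here, only one measured step bears on this change, and it swaps a different pair of groups: an at least 1.6-fold higher number from compound 1 to compound 2 (0.21 log units; that floor lies within the scatter). That step gives no sign of a large effect, so no step beyond the scatter is expected in this assay. The expected step is an at least 1.3-fold lower number from compound 2 to compound 3 (0.14 log units; that floor lies within the scatter). Compound 3 is estimated at 18000 nM, with an expected range of 6000 nM to 40000 nM.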

Compound 3, half-maximal inhibitory concentration: > 25000 nM
Compound 3: a limit, no number (the forecaster's own chance of this, stated with the estimate: 45%); middle value at least 1.3-fold (0.14 log units) from the limit.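

In this assay compound 3, with nitro on this aromatic carbon, also gives only a limit, so methoxy and nitro both leave the read-out without a number. Against acetoxy, the comparison gives an at least 1.6-fold higher number from compound 1 to compound 3 (0.21 log units; that floor lies within the scatter), so nitro is not separated from acetoxy beyond the scatter. The step between the methoxy and nitro compounds cannot be read, because both sit at the same limit: the limit of > 25000 nM in this assay, at which 2 of the 3 values shown sit.

Going by these compounds, how far methoxy and nitro truly lie apart stays open. So does whether an amine or a carboxylic acid on this carbon would give a measurable number.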